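The source may hold more compounds than are shown below. What is called first, only, known or untested is meant among the compounds shown, and "the series" means these compounds.

Compounds measured so far:
compound 1 `Cc1ccc(S(=O)(=O)N(Cc2nnc(Cc3ccccc3F)o2)c2cccc(Cl)c2C)cc1` — 631 nM
compound 2 `Cc1ccc(S(=O)(=O)N(Cc2nnc(Cc3c(Cl)cccc3Cl)o2)c2cccc(Cl)c2C)cc1` — 501 nM

The study concerns a functional assay on CHO cells for antagonist activity at prostaglandin E2 receptor EP1 subtype (Homo sapiens), read by FLIPR and calcium flux; a higher number here means a weaker inhibitor, a lower number a stronger inhibitor. Compound 1 gives 631 nM, and compound 2 gives 501 nM. Going by the values given here, compound 2 has the lowest of the two numbers so far, but its only neighbour is compound 1, and the gap between them is a 1.3-fold lower number from compound 1 to compound 2 (0.10 log units; within the scatter), so the two cannot be told apart on these data.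

The step now followed leads from compound 2 to compound 3 `Cc1ccc(S(=O)(=O)N(Cc2nnc(Cc3ccc(Cl)cc3Cl)o2)c2cccc(Cl)c2C)cc1`. The change is 2,4-dichlorophenyl in place of 2,6-dichlorophenyl on a saturated chain carbon bound to an aromatic carbon; cut one bond further out, it reads 2,6-dichlorobenzyl to 2,4-dichlorobenzyl. Among the compounds with values here, the single measured step that touches this part of the molecule is a 1.3-fold lower number from compound 1 to compound 2 (0.10 log units; within the scatter), which exchanged one halogenated phenyl for another at the same place and stayed within the scatter. Within the data shown here, no measured pair compares two dichlorophenyl groups differing only in where their chlorines sit, so the expectation for compound 3 rests on that one uninformative step alone. A step in this assay of about a 1.2-fold higher number from compound 2 to compound 3 (0.08 log units; within the scatter) is therefore expected, with no direction that can be backed by the numbers. Compound 3 is accordingly estimated at 600 nM, within a range of 250 nM to 1500 nM.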

Compound 3, inhibition constant: 1000 nM
Beside the measured number, compound 3's estimate is 1.7-fold (0.22 log units) below it; low and high end bracket the measured number.
By their numbers in this assay, from the lowest: compounds 2, 1 and 3 (each within the scatter of the next).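

Going by these compounds alone, compound 3 gives the first comparison at this place of two dichlorophenyl groups made of the same atoms and joined differently: in this assay, moving the chlorines yields a 2.0-fold higher number from compound 2 to compound 3 (0.30 log units; within the scatter), the largest step seen so far, yet 2,4-dichlorophenyl and 2,6-dichlorophenyl still cannot be told apart. Exchanging the 2-fluorophenyl group for 2,4-dichlorophenyl gives a 1.6-fold higher number from compound 1 to compound 3 (0.20 log units; within the scatter), so all three pairs among these halogenated phenyl groups on a saturated chain carbon bound to an aromatic carbon lie within the scatter, and neither the chlorine arrangement nor the choice between one fluorine and two chlorines has yet been shown to matter here. No measurement at hand offers an explanation for these numbers.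

What the compounds shown leave open is whether any group at this place can move the number beyond the scatter, since all three carry a halogenated phenyl ring. An unsubstituted phenyl, a pyridine ring, or a phenyl ring bearing a methoxy group or a carboxylic acid would test this, and the rest of the shared core stays unexamined.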